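From compound 2 to compound 4: a second ethyl

The compounds below may be only part of what the source reports. "The series", "measured", "known", "first", "only" and "open" are said of these compounds alone.

Compounds in this series share one core and differ in the group on an amide-type nitrogen. In a functional assay on T-24 cells (Homo sapiens) for antiproliferative activity, read by MTT assay, with a stated time of 48 h (a higher number here means a weaker inhibitor, a lower number a stronger inhibitor), compound 1 `O=C(Nc1cccc(CNc2nccnc2Cl)c1)NC1CCCC1` reaches only a limit of the assay (> 40000 nM). Compound 2 `CCc1ccccc1NC(=O)Nc1cccc(CNc2nccnc2Cl)c1` gives a number (8720 nM). Compound 3 `Cc1ccc(NC(=O)Nc2cccc(CNc3nccnc3Cl)c2)cc1` also gives a number (9820 nM). For the measured compounds named here, the step of a 1.1-fold higher number from compound 2 to compound 3 (0.05 log units; within the scatter) leaves these two level, so compound 2 stands with compound 3 as one of only two numbers.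

Compound 4 `CCc1ccc(NC(=O)Nc2cccc(CNc3nccnc3Cl)c2)c(CC)c1` carries ethyl in place of hydrogen on an aromatic carbon with ethyl in place of hydrogen on an aromatic carbon, meta to an ethyl group and para to a large group.

Going by the values given here, no measured step adds a group to a phenyl ring that already carries one. The nearest guide is the step of a 1.1-fold higher number from compound 2 to compound 3 (0.05 log units; within the scatter) with its 4-methylphenyl in place of 2-ethylphenyl, which stays within the scatter. The steps of an at least 4.5-fold lower number from compound 1 to compound 2 (0.66 log units; beyond the scatter) and an at least 4.0-fold lower number from compound 1 to compound 3 (0.60 log units; beyond the scatter) show that both phenyl groups give numbers where cyclopentyl gives a limit, and the same is expected of the new group. The expected change is a 1.2-fold lower number from compound 2 to compound 4 (0.07 log units; within the scatter) in this assay and is estimated to remain within the scatter. For compound 4 the estimated value is 7500 nM with an expected range of 3000 nM to 20000 nM in this series.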

Compound 4, half-maximal inhibitory concentration: 6390 nM
Beside the measured number, compound 4's estimate is 1.2-fold (0.07 log units) above it, within the range that was stated.
By their numbers in this assay, from the lowest: compounds 4, 2 and 3 (each within the scatter of the next). At a limit, above all of these: compound 1.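

In this assay, the one shown addition to a phenyl ring that already carries a group gives a 1.4-fold lower number from compound 2 to compound 4 (0.14 log units; within the scatter), so compound 4 stands level with compound 2. For the compounds shown here, this aromatic carbon, meta to an ethyl group and para to a large group, therefore accepts ethyl in place of hydrogen without a change beyond the scatter, which the earlier compounds could not show because none of them carries a second group on that ring. Compound 1 remains the only compound at a limit of the assay: the limit of > 40000 nM in this assay, at which 1 of the 4 values shown sits.

What an amine, a carboxylic acid or a longer chain on this aromatic carbon would do in this assay remains open, and with ethyl as the only group shown there, the result describes one substituent rather than the position as a whole. Also open is whether any change on the phenyl group can move the number beyond the scatter, since the steps shown among the phenyl compounds, a 1.1-fold higher number from compound 2 to compound 3 (0.05 log units; within the scatter) and the step to compound 4 above, both stay within it.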